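This account rests on a few compounds, and the source may have more. Where it says the series, first, only, none or still open, it means among the compounds named here.

Series notes. Compound 1 `COC(=O)c1sc2cc(-c3ccc(-c4cccs4)s3)cnc2c1N` and compound 2 `COC(=O)c1sc2cc(-c3ccoc3)cnc2c1N` share a core and differ in the aryl group attached to it. In a functional assay on NCI-H460 cells (Homo sapiens) for inhibition, read by sulforhodamine B assay, with a stated time of 48 h (a lower number here means a stronger inhibitor of growth, a higher number a weaker inhibitor of growth), compound 1 gives 700 nM. Compound 2 gives a limit rather than a number in this assay, > 120000 nM. Compound 2 thus sits at the limit of > 120000 nM in this assay, at which 1 of the 2 values shown sits, the weaker end of what has been shown so far. Compound 3 `COC(=O)c1sc2cc(-c3ccc(N)cc3)cnc2c1N` has not yet been tested. Against compound 2 the change is 4-aminophenyl in place of furan-3-yl on an aromatic carbon. Among the measured compounds shown here, no measured step between two compounds differing in one place exists, so the expectation rests on what compound 1 and compound 2 show: a larger aryl group went with a number, the furan-3-yl with a limit. A gain beyond the scatter is expected, and the step of an at least 6.0-fold lower number from compound 2 to compound 3 (0.77 log units; beyond the scatter) is estimated toward stronger inhibition. Compound 3 is therefore expected near 20000 nM, within 3000 nM to 120000 nM, with a real chance that again only a limit is reported.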

Compound 3, concentration for 50% growth inhibition: 37100 nM
Beside the measured number, compound 3's estimate is 1.9-fold (0.27 log units) below it; the measured number falls inside the stated range.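

In this assay a single six-membered aromatic ring of carbon only, the 4-aminophenyl, gives a measured number on this aromatic carbon, so a number here is not confined to the larger aryl group of compound 1. The change from furan-3-yl to 4-aminophenyl brings an at least 3.2-fold lower number from compound 2 to compound 3 (0.50 log units; beyond the scatter). That size is only a lower bound because compound 2 is a limit and not a number: the limit of > 120000 nM in this assay, at which 1 of the 3 values shown sits.

Open, on these data alone, is what the amine of the 4-aminophenyl contributes, set against an unsubstituted phenyl or a 4-hydroxyphenyl on the same carbon. Also open, as far as these compounds go, is how much of the distance from compound 3 at 37100 nM to compound 1 at 700 nM could be covered by a second aromatic ring on the 4-aminophenyl's place.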